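Substance-P receptor series: replacing the arylsulfonamide on the core

The source may hold more compounds than are shown below. What is called first, only, known or untested is meant among the compounds shown, and "the series" means these compounds.

Within the data shown here, compound 1 `C[C@@H](O[C@H]1CN2C(=O)C=C(c3ccc(NS(C)(=O)=O)cc3)CC2[C@@H]1c1ccc(F)cc1)c1cc(C(F)(F)F)cc(C(F)(F)F)c1` gives 1 nM in an assay on CHO cells for displacement of a labelled ligand from Substance-P receptor (Homo sapiens) (a higher number here means a weaker inhibitor, a lower number a stronger inhibitor), the highest of the three numbers measured so far. Compound 2 `C[C@@H](O[C@H]1CN2C(=O)C=C(c3cc[nH]c(=O)c3)CC2[C@@H]1c1ccc(F)cc1)c1cc(C(F)(F)F)cc(C(F)(F)F)c1` gives 0.27 nM and compound 3 `C[C@@H](O[C@H]1CN2C(=O)C=C(c3cnn(C)c3)CC2[C@@H]1c1ccc(F)cc1)c1cc(C(F)(F)F)cc(C(F)(F)F)c1` gives 0.13 nM; both steps, a 3.7-fold lower number from compound 1 to compound 2 (0.57 log units; beyond the scatter) and a 7.7-fold lower number from compound 1 to compound 3 (0.89 log units; beyond the scatter), run downward when a smaller heteroaryl group replaces the 4-(methanesulfonamido)phenyl. Compound 4 `C[C@@H](O[C@H]1CN2C(=O)C=C(C3=CCOCC3)CC2[C@@H]1c1ccc(F)cc1)c1cc(C(F)(F)F)cc(C(F)(F)F)c1` takes the same position with a different change: a group of 6 heavy atoms (5 carbon, 1 oxygen; one six-membered non-aromatic ring with 1 hetero atom) in place of a group of 11 heavy atoms (7 carbon, 1 nitrogen, 2 oxygen, 1 sulfur; one six-membered aromatic ring of carbon only), on a double-bonded ring carbon. Among the measured compounds shown here, no measured step covers a non-aromatic ring here, so the two downward steps are only a loose guide. A modest lowering is expected, so that compound 4 is estimated at 0.5 nM (range 0.15 nM to 1.6 nM), a step of a 2.0-fold lower number from compound 1 to compound 4 (0.30 log units; within the scatter).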

Compound 4, half-maximal inhibitory concentration: 0.18 nM
Compound 4: the middle estimate sits 2.8-fold (0.44 log units) above what was measured, and the stated range covers the measured number.
By their numbers in this assay, from the lowest: compounds 3, 4 and 2 (each within the scatter of the next, the first and the last beyond it); then compound 1.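

In this assay the non-aromatic ring on the double-bonded ring carbon gives a 5.6-fold lower number from compound 1 to compound 4 (0.74 log units; beyond the scatter) in the same direction as the heteroaryl groups, while a 1.4-fold higher number from compound 3 to compound 4 (0.14 log units; within the scatter) and a 1.5-fold lower number from compound 2 to compound 4 (0.18 log units; within the scatter) separate compound 4 from neither compound 3 nor compound 2. An aromatic ring at this position is therefore not required for a number this low, and an entering group with no hydrogen-bond donor suffices. Nothing available explains these steps. Open, from the compounds shown here alone, is how a ring carrying an amine or a carboxylic acid, or an open alkyl chain, would fare at this position.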